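The source may report more compounds than this note shows. Statements on the series, on what has been measured and on what is new or still open speak of the compounds shown alone.

Measured in a functional assay on HepG2 cells (Homo sapiens) for inhibition, read by MTT assay, with a stated time of 48 h; a lower number here means a stronger inhibitor, a higher number a weaker inhibitor:
Compound 1 `CCSc1nnc(-c2cc(OC)c(OC)c(OC)c2)n1-c1ccc(N(C)C)cc1`: > 60000 nM, a limit.
Compound 2 `COc1cc(-c2nnc(SCc3ccc(F)cc3)n2-c2ccc(N(C)C)cc2)cc(OC)c1OC`: 26400 nM.

Among the measured compounds shown here, compound 2 gives the only actual number so far, at 26400 nM. The one other result, for compound 1, is a limit. Compound 3 `COc1cc(-c2nnc(SCC(=O)c3ccc(F)cc3)n2-c2ccc(N(C)C)cc2)cc(OC)c1OC` keeps the core of compound 2 and places (4-fluorophenyl)carbonyl in place of 4-fluorophenyl on a saturated chain carbon bound to a sulfur. For the measured compounds named here, one measured step bears on this place: an at least 2.2-fold lower number from compound 1 to compound 2 (0.35 log units; beyond the scatter). On these data alone, that step is at least modest, but its full size is unknown, as one end rests on (the limit of > 60000 nM in this assay, at which 1 of the 2 values shown sits). It also concerns a different exchange, and the 4-fluorophenyl ring remains in compound 3, so it sets no direction here. The step of a 1.2-fold lower number from compound 2 to compound 3 (0.08 log units; within the scatter) is therefore expected to stay within the scatter in this assay. For compound 3 the estimated value is 22000 nM, with an expected range of 8000 nM to 60000 nM.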

Compound 3, half-maximal inhibitory concentration: > 60000 nM
Compound 3 ended at the assay's limit; the forecaster's own chance of this, stated with the estimate: 15%; middle value at least 2.7-fold (0.43 log units) from the limit.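

In this assay, (4-fluorophenyl)carbonyl in place of 4-fluorophenyl on a saturated chain carbon bound to a sulfur gives an at least 2.2-fold higher number from compound 2 to compound 3 (0.35 log units; beyond the scatter). Keeping the 4-fluorophenyl ring therefore does not by itself keep the measurable value seen for compound 2, and the change reverses the direction of the step from compound 1 to compound 2. The step between compound 1 and compound 3 cannot be read, and the size of the step to compound 3 stays open, because both results rest on the same limit: the limit of > 60000 nM in this assay, at which 2 of the 3 values shown sit.

Still open, on these data alone, is how an amine, a carboxylic acid or a longer chain ending in the 4-fluorophenyl ring would read at this place in this assay. Among the compounds shown here, with only one actual number, no finer order of groups at this place can be drawn.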